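Chromene series: anilide replaces methoxyphenyl on the triazole nitrogen

This account rests on a few compounds, and the source may have more. Where it says the series, first, only, none or still open, it means among the compounds named here.

Compound 1 `CCOC(=O)C1=Cc2ccccc2OC1(OCc1cn(-c2cccc(OC)c2)nn1)C(F)(F)F` is the reference point of this set. In a functional assay on A549 cells (Homo sapiens) for inhibition, read by MTT assay, with a stated time of 24 h (on this read-out lower numbers stand for stronger inhibition and higher numbers for weaker inhibition), compound 1 gives > 150000 nM, which is a limit of the assay and not a measured number. Compound 3 `CCOC(=O)C1=Cc2ccccc2OC1(OCc1cc(-c2ccc(OC)cc2)no1)C(F)(F)F` in this assay also gives > 150000 nM, again a limit rather than a number. Among the compounds with values here, compound 2 `Cc1ccc(-c2cc(COC3(C(F)(F)F)Oc4ccccc4C=C3C(=O)O)on2)cc1` is the only member with a measured figure, giving 51200 nM in this assay. Compound 1 therefore sits at the weak end of what is shown, at the limit (the limit of > 150000 nM in this assay, at which 2 of the 3 values shown sit), with compound 2 the only value standing inside the measured range.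

Compound 4 `CCOC(=O)C1=Cc2ccccc2OC1(OCc1cn(CC(=O)Nc2ccc(I)cc2Cl)nn1)C(F)(F)F` is not yet measured. It differs from compound 1 by ((2-chloro-4-iodophenyl)carbamoyl)methyl in place of 3-methoxyphenyl on an aromatic nitrogen. Within the data shown here, no step between measured compounds is available, so any expectation rests only on where compound 1 stands and on the change itself. The step from compound 1 to compound 4 is expected to be an at least 1.5-fold lower number from compound 1 to compound 4 (0.17 log units; that floor lies within the scatter), a modest move toward stronger inhibition at most. Compound 4 is expected to give 100000 nM in this assay, with a range from 30000 nM to 300000 nM.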

Compound 4, half-maximal inhibitory concentration: 22300 nM
Compound 4: the middle estimate sits 4.5-fold (0.65 log units) above what was measured, outside the stated range (below it).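

In this assay, the aromatic nitrogen of the five-membered aromatic ring with 3 nitrogen responds to substitution: ((2-chloro-4-iodophenyl)carbamoyl)methyl in place of 3-methoxyphenyl gives an at least 6.7-fold lower number from compound 1 to compound 4 (0.82 log units; beyond the scatter). Compound 4 keeps the ethyl ester of compound 1 and still gives a number inside the measured range. The step is only a floor, since compound 1 stands at a limit of the assay and not at a number: the limit of > 150000 nM in this assay, at which 2 of the 4 values shown sit.

The change replaces the whole group at once, so the separate contributions of the amide hydrogen, the chlorine and the iodine cannot be told apart. From the compounds shown here alone, how a longer chain carrying the same amide, or a dimethylamino group, would read on this nitrogen stays open.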